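Cyclopropyl to methyl on the ring nitrogen amine

The source may report more compounds than this note shows. Statements on the series, on what has been measured and on what is new or still open speak of the compounds shown alone.

Compounds measured so far in an ADME assay on MT4 cells (Homo sapiens) for cytotoxicity, read by MTT assay, with a stated time of 4 days; on this read-out higher numbers stand for lower toxicity in this test and lower numbers for higher toxicity in this test:
compound 1 `Cc1cc(C)cc(Cn2c(=O)cc(NC3CC3)n(Cc3ccccc3)c2=O)c1` gives > 100000 nM
compound 2 `Cc1cc(C)cc(Cn2c(=O)cc(NCc3ccccc3)n(Cc3ccccc3)c2=O)c1` gives > 100000 nM
compound 3 `Cc1cc(C)cc(Cn2c(=O)cc(N3CCCCC3)n(Cc3ccccc3)c2=O)c1` gives 47000 nM

Compound 1 reports only a limit of the assay, not a number. Compound 2 also sits at a limit of the assay. Compound 3 gives a number, and the step of an at least 2.1-fold lower number from compound 1 to compound 3 (0.32 log units; beyond the scatter) comes with a piperidin-1-yl in place of cyclopropylamino on an aromatic carbon; the step of an at least 2.1-fold lower number from compound 2 to compound 3 (0.32 log units; beyond the scatter) reads the same way for benzylamino.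

Compound 4 `CNc1cc(=O)n(Cc2cc(C)cc(C)c2)c(=O)n1Cc1ccccc1` differs from compound 1 by methyl in place of cyclopropyl on a nitrogen on an aromatic ring. The nearest measured step at the same nitrogen is a step that the two limits leave unreadable from compound 1 to compound 2, which the two limits leave unreadable; the exchange there is benzyl for cyclopropyl, a larger group than the methyl entering here. Both amino-substituted compounds sit at the limit of > 100000 nM in this assay, at which 2 of the 3 values shown sit. Going by the values given here, no measured step bears directly on a methyl at this nitrogen, so no step beyond the scatter is expected, and the result for compound 4 is expected to be another limit more often than not.

Compound 4 is therefore estimated at 100000 nM (range 45000 nM to 250000 nM), an expected step of a number no higher from compound 1 to compound 4 (the limit leaves the size open).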

Compound 4, half-maximal cytotoxic concentration: 65000 nM
Estimate against measurement, compound 4: 1.5-fold (0.19 log units) above, and the stated range covers the measured number.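

In this assay, going by these compounds alone, compound 4 is the first compound with a substituent and a hydrogen on this amino nitrogen to give a readable number rather than a limit. Methyl in place of cyclopropyl gives an at least 1.5-fold lower number from compound 1 to compound 4 (0.18 log units; that floor lies within the scatter), and the comparison with the benzylamino compound gives an at least 1.5-fold lower number from compound 2 to compound 4 (0.18 log units; that floor lies within the scatter), so neither step establishes a real change. The comparison with the piperidin-1-yl compound gives a 1.4-fold higher number from compound 3 to compound 4 (0.14 log units; within the scatter), so these two groups cannot be told apart, and a readable value in this range is no longer confined to piperidin-1-yl.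

On these data alone, the true values of compound 1 and compound 2 remain unknown, which leaves the full size of both steps open: the limit of > 100000 nM in this assay, at which 2 of the 4 values shown sit. Whether ethylamino or dimethylamino would read like compound 4 or reach the limit also stays open.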